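Removing the (dimethylamino)methyl group from compound 2

The source may hold more compounds than are shown below. What is called first, only, known or untested is meant among the compounds shown, and "the series" means these compounds.

Measured so far in a physicochemical assay for solubility, read by LC-MS, in phosphate buffer, with a stated time of 24 h, at pH 7.4; a lower number here means a less soluble compound, a higher number a more soluble compound:
compound 1 `O=C1CCCN1c1cnc(NCc2c(F)ccc3c2CCO3)n2cnnc12`, 640000 nM;
compound 2 `Cc1nc(CN(C)C)ccc1-c1cnc(NCc2c(F)ccc3c2CCO3)c2cn[nH]c(=O)c12`, a limit of > 1000000 nM;
compound 3 `O=C(Nc1cnc(NCc2c(F)ccc3c2CCO3)n2cnnc12)c1cccnc1`, 12000 nM.

Compound 2 sits at the limit of > 1000000 nM in this assay, at which 1 of the 3 values shown sits, so its value is a limit, not a number. Compound 4 `Cc1ncccc1-c1cnc(NCc2c(F)ccc3c2CCO3)c2cn[nH]c(=O)c12` differs from it in one place: hydrogen in place of (dimethylamino)methyl on an aromatic carbon. Going by the values given here, the only measured step, a 53-fold lower number from compound 1 to compound 3 (1.73 log units; beyond the scatter), concerns a different change on a different core and does not bear on this one, so the comparison rests on the structures alone. Compound 4 is estimated at 150000 nM, within 30000 nM to 1000000 nM, which corresponds to an expected step of an at least 6.6-fold lower number from compound 2 to compound 4 (0.82 log units; beyond the scatter).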

Compound 4, solubility: < 2000 nM
Compound 4: a limit, no number; the forecaster's own chance of this, stated with the estimate: 20%; at least 75-fold (1.87 log units) between middle value and limit.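

In this assay, going by these compounds alone, hydrogen in place of (dimethylamino)methyl on an aromatic carbon next to the ring nitrogen gives an at least 500-fold lower number from compound 2 to compound 4 (2.69 log units; beyond the scatter) and is the first step read at this position. Compound 4 stands at a limit, not a number: the limit of < 2000 nM in this assay, at which 1 of the 4 values shown sits. Compound 2 also stands at a limit, not a number: the limit of > 1000000 nM in this assay, at which 1 of the 4 values shown sits.

From the compounds shown here alone, the true size of the step therefore stays open. Also open, going by these compounds, is whether a primary amine, a carboxylic acid or a longer chain ending in dimethylamino at this position would read like compound 2 or like compound 4.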